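The source may hold more compounds than are shown below. What is called first, only, known or untested is meant among the compounds shown, and "the series" means these compounds.

Measured in a functional assay on DU-145 cells (Homo sapiens) for cytotoxicity, read by MTT assay, with a stated time of 2 days; a lower number here means a stronger inhibitor, a higher number a weaker inhibitor:
compound 1 `CCCCCNc1nc(NCc2ccco2)c2cc(F)ccc2n1`, 7240 nM
compound 2 `Clc1cccc(N2CCN(CCCCNc3nc(NCc4ccco4)c4ccccc4n3)CC2)c1Cl`, 3870 nM
compound 3 `Fc1ccc2nc(NCCCCN3CCN(c4cccc(Cl)c4Cl)CC3)nc(NCc3ccco3)c2c1`, 670 nM

Compound 1 carries the highest number of the three; compound 2 sits within the usual scatter of it, while the value of compound 3 lies well below that of compound 1. Among the compounds with values here, the single one-place step among the measured compounds, a 5.8-fold lower number from compound 2 to compound 3 (0.76 log units; beyond the scatter), concerns the fluoro substituent on the core and not the amine side chain. Compound 4 `COc1ccc(Nc2nc(NCc3ccco3)c3cc(F)ccc3n2)cc1` departs from compound 1 by 4-methoxyphenyl in place of pentyl on a nitrogen on an aromatic ring. Within the data shown here, no measured pair covers this change, so nothing here fixes its size or direction; the step from compound 1 to compound 4 is expected to be a 1.8-fold lower number from compound 1 to compound 4 (0.26 log units; within the scatter), held loosely. Compound 4 is estimated at 4000 nM in this assay, with a range of 800 nM to 20000 nM.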

Compound 4, half-maximal inhibitory concentration: 11600 nM
Beside the measured number, compound 4's estimate is 2.9-fold (0.46 log units) below it; low and high end bracket the measured number.
By their numbers in this assay, from the lowest: compound 3; then compounds 2, 1 and 4 (each within the scatter of the next, the first and the last beyond it).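

In this assay, placing 4-methoxyphenyl instead of pentyl on the nitrogen of the core of compound 1 gives a 1.6-fold higher number from compound 1 to compound 4 (0.20 log units; within the scatter) and so no readable shift. At this position, with the fluoro core held fixed, an open chain and a six-membered aromatic ring carrying methoxy therefore read alike. No measured property bears on this result, so it carries no explanation. Open, from the compounds shown here alone, is how phenyl without the methoxy, 4-chlorophenyl or a longer alkyl chain would read on this nitrogen.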